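Thiosemicarbazide series: morpholine in place of pyrrolidine

A few compounds are considered here, and "the series" means these few. Any claim that something is new, unique, unknown or untested is made for them only; others in the source may bear on it.

Compound 1 `Cc1ccnc(/C(N)=N/NC(=S)N2CCCC2)c1` and compound 2 `Cc1cccc(/C(N)=N/NC(=S)N2CCCC2)n1` differ only in the placement of the methyl on the pyridine-type ring. In a functional assay on HeLa cells (Homo sapiens) for cytotoxicity, read by MTT assay, with a stated time of 72 h, tested at 100 uM (on this read-out higher numbers stand for more inhibition of growth at the one concentration tested and lower numbers for less inhibition of growth), compound 1 gives 88.1%, and compound 2 gives 80.1%; of the two numbers, compound 1 holds the higher, but the gap to compound 2 lies within the scatter. Compound 3 `Cc1ccnc(/C(N)=N/NC(=S)N2CCOCC2)c1` is not yet measured. It differs from compound 1 by morpholin-4-yl in place of pyrrolidin-1-yl on a thiocarbonyl carbon. Among the compounds with values here, no measured pair shows this change, so the expected step from compound 1 to compound 3 is small, a number 8.1 percentage points lower from compound 1 to compound 3 (within the scatter), and likely not beyond the scatter. Compound 3 is estimated at 80%, with a range from 60% to 95%.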

Compound 3, percent growth inhibition at one concentration: 82.7%
Compound 3: the middle estimate sits 2.7 percentage points below what was measured; the range from low to high includes it.
By their numbers in this assay, from the lowest: compounds 2, 3 and 1 (each within the scatter of the next).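

In this assay, within the data shown here, the first pair for this change gives a number 5.4 percentage points lower from compound 1 to compound 3 (within the scatter), so the thiocarbonyl carbon carries morpholin-4-yl, with its ring oxygen and larger ring, in place of pyrrolidin-1-yl without a step beyond the scatter. No supporting data bear on why the number stays within that range. Open, as far as these compounds go, is whether piperidin-1-yl or an open-chain dimethylamino group on the same carbon would also stay within the scatter of compound 1. Also open, from the compounds shown here alone, is whether morpholin-4-yl gives a similar step on the core of compound 2.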